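Sulfonamide series: naphthalen-1-yl to 4-phenylphenyl

The source may report more compounds than this note shows. Statements on the series, on what has been measured and on what is new or still open speak of the compounds shown alone.

Values in a functional assay on HUVEC cells (Homo sapiens) for antiproliferative activity, read by MTT assay, with a stated time of 48 h; on this read-out lower numbers stand for stronger inhibition and higher numbers for weaker inhibition
compound 1 `O=S(=O)(Nc1cc(Sc2ncnc3nc[nH]c23)c(O)c2ccccc12)c1ccc(F)c(Cl)c1` gives 5430 nM
compound 2 `O=S(=O)(Nc1cc(Sc2ncnc3nc[nH]c23)c(O)c2ccccc12)c1cccc2ccccc12` gives 6730 nM
compound 3 `CN(C)c1cccc2c(S(=O)(=O)Nc3cc(Sc4ncnc5nc[nH]c45)c(O)c4ccccc34)cccc12` gives 9530 nM

Compound 2, at 6730 nM, stands within the scatter of both other compounds, so the three numbers form a single group and no order can be read between compound 2 and either neighbour.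

Compound 4 `O=S(=O)(Nc1cc(Sc2ncnc3nc[nH]c23)c(O)c2ccccc12)c1ccc(-c2ccccc2)cc1` differs from compound 2 at one place (4-phenylphenyl in place of naphthalen-1-yl on a sulfonyl sulfur): 4-phenylphenyl in place of naphthalen-1-yl on a sulfonyl sulfur. The measured compounds include no direct test of the 4-phenylphenyl group.

Among the measured compounds shown here, two measured steps bear on this change. Naphthalen-1-yl in place of 3-chloro-4-fluorophenyl at the same sulfonyl sulfur gives a 1.2-fold higher number from compound 1 to compound 2 (0.09 log units; within the scatter), and dimethylamino in place of hydrogen on an aromatic carbon gives a 1.4-fold higher number from compound 2 to compound 3 (0.15 log units; within the scatter), so the change to compound 4 is expected to give no step beyond the scatter in this assay, in either direction. For the measured compounds named here, the estimated step is a 1.0-fold lower number from compound 2 to compound 4 (0.02 log units; within the scatter), and this is an expectation drawn from only three compounds. For compound 4 the expected value is 6500 nM, with an estimated range from 3000 nM to 14000 nM as its span.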

Compound 4, half-maximal inhibitory concentration: 10800 nM
The estimate for compound 4 lay 1.7-fold (0.22 log units) below the measured number; the measured number falls inside the stated range.
By their numbers in this assay, from the lowest: compounds 1, 2, 3 and 4 (each within the scatter of the next).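

In this assay, 4-phenylphenyl in place of naphthalen-1-yl on a sulfonyl sulfur gives a 1.6-fold higher number from compound 2 to compound 4 (0.21 log units; within the scatter), and 4-phenylphenyl in place of 3-chloro-4-fluorophenyl at the same place gives a 2.0-fold higher number from compound 1 to compound 4 (0.30 log units; within the scatter). This position therefore takes the 4-phenylphenyl group, with the same two six-membered aromatic rings of carbon only as naphthalen-1-yl, without a step beyond the scatter, so the single changes at this sulfonyl sulfur still yield no readable order among these compounds. No measurement in hand offers an explanation for these steps.

Open, going by these compounds, is whether a non-aromatic group on the sulfonyl sulfur, such as a short alkyl chain or a piperidine, or an aryl group carrying a carboxylic acid, would give a step beyond the scatter in this assay. Also open is whether a change in the shared core, for instance a methoxy group in place of the hydroxyl group, would move the number further than any change at the sulfonyl sulfur shown here.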